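Cinnamoyl amide replacing thiophene carboxamide in octylamide series

The source may report more compounds than this note shows. Statements on the series, on what has been measured and on what is new or still open speak of the compounds shown alone.

Two members of the series carry measurements. Compound 1 `CCCCCCCCNC(=O)[C@@H](NC(=O)c1ccccc1)[C@@H](C)O` in a functional assay on SW-620 cells (Homo sapiens) for cytotoxicity, read by MTT assay, with a stated time of 48 h (a lower number here means a stronger inhibitor, a higher number a weaker inhibitor), gives 200000 nM. Compound 2 `CCCCCCCCNC(=O)[C@@H](NC(=O)c1cccs1)[C@@H](C)O` in this assay gives 136000 nM. Within the data shown here, the single measured step, a 1.5-fold lower number from compound 1 to compound 2 (0.17 log units; within the scatter), is the only guide available, and it places the two numbers within the scatter of each other, so no ordering between compound 1 and compound 2 can be read from it.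

Compound 3 `CCCCCCCCNC(=O)[C@@H](NC(=O)/C=C/c1ccccc1)[C@@H](C)O` is not yet measured. Relative to compound 2 the change is 2-phenylethenyl in place of thiophen-2-yl on a carbonyl carbon. The measured step from compound 1 to compound 2 bears on this only loosely: it shows that exchanging one aromatic group on that carbonyl carbon for another moved the number by a 1.5-fold lower number from compound 1 to compound 2 (0.17 log units; within the scatter), which is within the scatter. Among the measured compounds shown here, compound 3 introduces a larger group with a double bond outside aromatic rings, for which no comparable step exists. On the evidence of compound 2 at 136000 nM and the small measured step, the expected step of a 1.1-fold lower number from compound 2 to compound 3 (0.05 log units; within the scatter) is no larger than the scatter. Compound 3 is therefore estimated at 120000 nM, with a range from 50000 nM to 300000 nM.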

Compound 3, half-maximal inhibitory concentration: 61400 nM
Compound 3: middle estimate off by 2.0-fold (0.29 log units), on the high side; low and high end bracket the measured number.
By their numbers in this assay, from the lowest: compound 3; then compounds 2 and 1 (each within the scatter of the next).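

In this assay, the position on a carbonyl carbon now gives a change beyond the scatter: 2-phenylethenyl yields a 2.2-fold lower number from compound 2 to compound 3 (0.35 log units; beyond the scatter) and a 3.3-fold lower number from compound 1 to compound 3 (0.51 log units; beyond the scatter), both modest, and compound 3 at 61400 nM has the lowest number of the three. The exchange of phenyl for thiophen-2-yl gave no readable order, whereas this exchange, which brings in a double bond outside aromatic rings and places a six-membered aromatic ring of carbon only within a group of more heavy atoms, separates compound 3 from both earlier compounds. No measurement at hand explains this shift.

The double bond and the added heavy atoms enter together, so the compounds shown cannot say which of them carries the step, and a 2-phenylethyl group on the same carbonyl carbon would bear directly on that question. The octyl chain stays the same throughout, which leaves open whether the step from 2-phenylethenyl would hold with a longer chain such as decyl, or whether a substituted ring such as 4-methoxyphenylethenyl would extend it.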